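The source may hold more compounds than are shown below. What is called first, only, known or untested is meant among the compounds shown, and "the series" means these compounds.

Measured so far in a functional assay on HCT-116 cells (Homo sapiens) for inhibition, read by MTT assay, with a stated time of 72 h; a higher number here means a weaker inhibitor, a lower number a stronger inhibitor:
- compound 1 `CCOC(=O)c1oc2ccc(N(Cc3ccccc3)S(=O)(=O)c3cccc(Br)c3)cc2c1C`: > 40000 nM, a limit of the assay
- compound 2 `CCOC(=O)c1oc2ccc(N(Cc3ccccc3)S(=O)(=O)c3ccc(OC)cc3)cc2c1C`: > 40000 nM, a limit of the assay
- compound 3 `CCOC(=O)c1oc2ccc(N(Cc3ccccc3)S(=O)(=O)c3ccc([N+](=O)[O-])cc3)cc2c1C`: > 40000 nM, a limit of the assay

Compound 1 stands only at a limit; no number places it against the others, since all three values sit at the limit of > 40000 nM in this assay, at which 3 of the 3 values shown sit. Compound 4 `CCOC(=O)c1oc2ccc(N(Cc3ccccc3)S(=O)(=O)c3ccc(F)cc3)cc2c1C` differs from compound 1 by 4-fluorophenyl in place of 3-bromophenyl on a sulfonyl sulfur. For the measured compounds named here, the steps that bear on a change on the sulfonyl sulfur, a step that the two limits leave unreadable from compound 1 to compound 2 and a step that the two limits leave unreadable from compound 1 to compound 3, and the further step that the two limits leave unreadable from compound 2 to compound 3, are all unreadable between limits. Going by the values given here, no measured step therefore gives a size or a direction, and in this assay compound 4 is expected to remain at the limit, with an expected step that the limit leaves unreadable from compound 1 to compound 4. The estimate for compound 4 is 60000 nM, range 20000 nM to 200000 nM.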

Compound 4, half-maximal inhibitory concentration: 33100 nM
Estimate against measurement, compound 4: 1.8-fold (0.26 log units) above; the measured number falls inside the stated range.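

In this assay, for the compounds shown here, compound 4 is the first compound here to give a number rather than a limit, so a change on the sulfonyl sulfur now has a readable floor. The steps are an at least 1.2-fold lower number from compound 1 to compound 4 (0.08 log units; that floor lies within the scatter), an at least 1.2-fold lower number from compound 2 to compound 4 (0.08 log units; that floor lies within the scatter) and an at least 1.2-fold lower number from compound 3 to compound 4 (0.08 log units; that floor lies within the scatter), so none is shown to lie beyond the scatter. The series therefore still rests largely on a single limit: the limit of > 40000 nM in this assay, at which 3 of the 4 values shown sit.

From the compounds shown here alone, the true size of all three steps remains open. So does how a 4-aminophenyl or a longer alkyl chain on the sulfonyl sulfur would read in this assay.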